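This account rests on a few compounds, and the source may have more. Where it says the series, first, only, none or still open, it means among the compounds named here.

Measured compounds:
- Compound 1, `C[C@@H](Nc1c(C(=O)NCc2ccc(F)cc2)nc(Br)c2cccnc12)c1ccccc1`: in a functional assay on MCF7 cells (Homo sapiens) for cytotoxicity, read by MTT assay, with a stated time of 72 h (a higher number here means a weaker inhibitor, a lower number a stronger inhibitor), compound 1 gives "not determined" (no result reported).
- Compound 2, `COc1ccc(CNC(=O)c2nc(Br)c3cccnc3c2N[C@H]2CC[C@H](N)CC2)cc1`: in this assay compound 2 gives "not determined" (no result reported).
- Compound 3, `CN(C)c1ccc(CNC(=O)c2nc(Br)c3cccnc3c2N[C@H]2CC[C@H](N)CC2)cc1`: in this assay compound 3 gives 5000 nM.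

Compound 1 stands nowhere on the numbers shown: it carries no result in this assay, and compound 2 is likewise without a result, so compound 3 is the only compound of the three with a number. Among the measured compounds shown here, no step between measured compounds exists, and no pattern across the series can be drawn from a single value.

Compound 4, `NCCCCCCNc1c(C(=O)NCc2ccc(F)cc2)nc(Br)c2cccnc12`, is the next compound for this assay. It differs from compound 1 in one place: 6-aminohexyl in place of 1-phenylethyl on a nitrogen on an aromatic ring. Compound 1 has no number in this assay, and the step from compound 1 to compound 4 cannot be sized or given a direction; the expectation for compound 4 can rest only on compound 3, which gives 5000 nM in this assay and shares the shared core and a primary amine on the nitrogen on the aromatic ring.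

Compound 4 is expected to give an estimated 5000 nM in this assay, with a range from 1500 nM to 20000 nM, the width reflecting that only compound 3 with 5000 nM anchors the estimate.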

Compound 4, half-maximal inhibitory concentration: 2000 nM
Beside the measured number, compound 4's estimate is 2.5-fold (0.40 log units) above it; the measured number falls inside the stated range.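

The step from compound 1 to compound 4 cannot be read in this assay, where compound 1 carries no single number. The compounds shown leave open how (6-aminohexyl)amino compares with (1-phenylethyl)amino on the shared core. No evidence bearing on this result is available.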